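The compounds below may be only part of what the source reports. "The series", "measured", "known", "first", "only" and "open" are said of these compounds alone.

Working notes on the series.

Compound 1 `O=C(Nc1cccc(-n2cc(-c3ccncc3)c(-c3ccc(Cl)c(O)c3)n2)c1)Nc1ccc(Cl)c(Cl)c1` is the anchor here. Going by the values given here, in a functional assay on KM12 cells (Homo sapiens) for inhibition, read by sulforhodamine B assay, with a stated time of 48 h (on this read-out higher numbers stand for lower toxicity in this test and lower numbers for higher toxicity in this test), compound 1 gives 26300 nM, the only numeric value so far in this set. Compound 2 `COc1cc(-c2nn(-c3cccc(NC(=O)c4ccc(Cl)c(C(F)(F)F)c4)c3)cc2-c2ccncc2)ccc1Cl` carries an amide rather than the urea of compound 1 and a methoxy in place of the hydroxy. In this assay compound 2 reaches only a limit of the assay, > 32500 nM; this is the situation summarised as the limit of > 32500 nM in this assay, at which 1 of the 2 values shown sits. Among the compounds with values here, no two measured compounds differ in one place, so no measured step is available.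

Compound 3 `O=C(Nc1cccc(-n2cc(-c3ccncc3)c(-c3ccc(Cl)c(O)c3)n2)c1)Nc1ccc(Cl)c(C(F)(F)F)c1` is the next to be read. It differs from compound 1 in one place: trifluoromethyl in place of chloro on an aromatic carbon. For this assay the expected step from compound 1 to compound 3 is small, no further than the usual scatter, and if anything towards a higher reading, given that compound 1 at 26300 nM already sits close to the top of the measured window; the estimated step is a 1.1-fold higher number from compound 1 to compound 3 (0.06 log units; within the scatter). For compound 3 the estimate in this assay is 30000 nM, with a range from 12000 nM to 60000 nM, and a fair chance that only a limit is reported.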

Compound 3, concentration lethal to 50% of the cells: 17400 nM
The estimate for compound 3 lay 1.7-fold (0.24 log units) above the measured number; the measured number falls inside the stated range.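

Going by these compounds alone, the change from 3,4-dichlorophenyl to 4-chloro-3-(trifluoromethyl)phenyl gives the first measured step: in this assay, the reading shows a 1.5-fold lower number from compound 1 to compound 3 (0.18 log units; within the scatter). This place, ortho to a chloro group and meta to a large group, therefore takes trifluoromethyl, with 4 heavy atoms, in place of chloro, with 1 heavy atom, and the reading stays within the usual scatter, so no effect of the change can be claimed. Compound 2 is a limit of the assay and not a number, and it differs from the others in more than one place, so it adds no step here: the limit of > 32500 nM in this assay, at which 1 of the 3 values shown sits.

From the compounds shown here alone, it remains open whether any group at this place can move the reading beyond the scatter, for example a nitrile, an amine or a carboxylic acid in place of the trifluoromethyl. Going by these compounds, it is equally open whether the same exchange of chloro for trifluoromethyl would read alike on a compound carrying an amine in place of the hydroxy on the other aromatic ring.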